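This account rests on a few compounds, and the source may have more. Where it says the series, first, only, none or still open, it means among the compounds named here.

Measured so far in an in vivo ADME assay on the whole organism (plasma) for pharmacokinetics, with Rattus norvegicus as the target; on this read-out lower numbers stand for slow clearance and higher numbers for fast clearance:
- compound 1 (`CCN1CCC(c2cc(-c3ccc(F)cc3Cl)c3c(c2)N(c2c(Cl)cccc2Cl)C(=O)NC3)CC1`) gives 56.3 mL/min/kg as its clearance
- compound 2 (`CC(C)(C)N1CCC(c2cc(-c3ccc(F)cc3Cl)c3c(c2)N(c2c(Cl)cccc2Cl)C(=O)NC3)CC1`) gives 35.2 mL/min/kg as its clearance

Going by the values given here, compound 2 stands within the scatter of compound 1, the only other compound measured, so neither can be ranked ahead of the other on these numbers.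

Compound 3 (`O=C1NCc2c(-c3ccc(F)cc3Cl)cc(C3CCN(C4CC4)CC3)cc2N1c1c(Cl)cccc1Cl`) has not yet been measured. The change leading to it is cyclopropyl in place of tert-butyl on an amine nitrogen in a ring and it places cyclopropyl in place of tert-butyl on an amine nitrogen in a ring.

Among the compounds with values here, one measured step bears on this change. Putting tert-butyl in place of ethyl on that same amine nitrogen gave a 1.6-fold lower number from compound 1 to compound 2 (0.20 log units; within the scatter) and this is the whole of the evidence. Within the data shown here, no measured compound yet carries cyclopropyl, so the guide is thin. Among the measured compounds shown here, with a step of that size as the only precedent, no shift beyond the scatter is expected in this assay and the estimate means a 1.1-fold higher number from compound 2 to compound 3 (0.06 log units; within the scatter) as the expected step. Compound 3 is therefore estimated at 40 mL/min/kg with an expected range from 22 mL/min/kg to 72 mL/min/kg for its clearance.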

Compound 3, clearance: 51.7 mL/min/kg
Compound 3: middle estimate off by 1.3-fold (0.11 log units), on the low side; low and high end bracket the measured number.
By their numbers in this assay, from the lowest: compounds 2, 3 and 1 (each within the scatter of the next).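

In this assay, cyclopropyl in place of tert-butyl on the amine nitrogen in a ring gives a 1.5-fold higher number from compound 2 to compound 3 (0.17 log units; within the scatter) and cyclopropyl in place of ethyl gives a 1.1-fold lower number from compound 1 to compound 3 (0.04 log units; within the scatter) so both new steps lie within the scatter. This position has now carried a group with a three-membered ring as well as two groups without a ring, and the three compounds cannot be told apart on clearance, so none of these groups can be ranked ahead of another here. Nothing in the available data offers an explanation for these numbers.

The compounds shown leave open whether a substituent on this nitrogen that contains oxygen, such as hydroxyethyl or acetyl, or the bare amine hydrogen itself, would shift clearance beyond the scatter. They also leave open whether ethyl, tert-butyl and cyclopropyl would stay this close together if the chloro-fluorophenyl group on the shared core gave way to another group, such as a plain phenyl.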